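The source may hold more compounds than are shown below. What is called first, only, known or untested is meant among the compounds shown, and "the series" means these compounds.

Measured compounds in an assay on HEK-293T cells for inhibition of diacylglycerol lipase-alpha (Homo sapiens), read by colorimetric assay; a higher number here means a weaker inhibitor, a lower number a stronger inhibitor:

compound 2 `CC(C)(C)C(=O)c1coc(C(=O)CCCCCCc2ccccc2)n1`: compound 2 gives 479 nM
compound 1 `O=C(CCCCCc1ccccc1)c1nc2cccc(F)c2o1`: compound 1 gives only a limit of the assay, > 10000 nM
compound 3 `CN(C)C(=O)c1cnc(C(=O)CCCCCCc2ccccc2)o1`: compound 3 likewise gives only a limit of the assay, > 10000 nM

Going by the values given here, compound 2 therefore stands alone: its value is the only number among the three, while the other two sit at the limit of the assay (the limit of > 10000 nM in this assay, at which 2 of the 3 values shown sit).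

The step under consideration goes from compound 2 to compound 4 `O=C(CCCCCCc1ccccc1)c1nc(-c2ccccc2)co1`. The change is phenyl in place of (tert-butyl)carbonyl on an aromatic carbon. Among the compounds with values here, no measured pair shows this exact change, so the size of the step in this assay can only be judged from what the three compounds show. Within the data shown here, compound 1 and compound 3, which both lack the (tert-butyl)carbonyl, sit at the limit (the limit of > 10000 nM in this assay, at which 2 of the 3 values shown sit), and compound 2, which carries it, gives the one number. On that basis compound 4 is expected to be weaker than compound 2, with the step from compound 2 to compound 4 estimated at a 17-fold higher number from compound 2 to compound 4 (1.22 log units; beyond the scatter). Compound 4 is estimated at 8000 nM, within a range of 2000 nM to 30000 nM, with a fair chance that only a limit is reported.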

Compound 4, half-maximal inhibitory concentration: 8710 nM
Estimate against measurement, compound 4: 1.1-fold (0.04 log units) below; low and high end bracket the measured number.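

Going by these compounds alone, at the aromatic carbon next to the ring nitrogen, phenyl in place of (tert-butyl)carbonyl gives in this assay an 18-fold higher number from compound 2 to compound 4 (1.26 log units; beyond the scatter) as the first step that can be read at this position. The two groups match in heavy atoms, so that count does not separate them; the change swaps a carbonyl with its hydrogen-bond acceptor for an aromatic ring of carbon only. Compound 4 still gives a number rather than a limit, so a measurable value here does not depend on the (tert-butyl)carbonyl, and the limit itself stands as before: the limit of > 10000 nM in this assay, at which 2 of the 4 values shown sit.

As far as these compounds go, whether the step follows from losing the carbonyl or from gaining the phenyl ring stays open. So does how a benzoyl or methoxycarbonyl group on this carbon would read, since either would keep the carbonyl while changing what it carries.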